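The compounds below may be only part of what the source reports. "The series", "measured", "known", "first", "only" and "open" are said of these compounds alone.

The series shares one core and is followed in an ADME assay on microsomes from liver (Homo sapiens) for metabolic stability; on this read-out lower numbers stand for slow clearance and higher numbers for fast clearance. Compound 1 `CC(C)n1nc(-c2ccnc3[nH]c(C4CCN(CC(=O)N(C)C)CC4)cc23)ccc1=O` gives 13 uL/min in this assay. Compound 2 `CN(C)C(=O)CN1CCC(c2cc3c(-c4ccc(=O)n(C)c4)ccnc3[nH]2)CC1` is reported in this assay only as a limit, < 3 uL/min. Between these two stands the single measured step, an at least 4.3-fold lower number from compound 1 to compound 2 (0.63 log units; beyond the scatter), which exchanges one ring group for another on an aromatic carbon. Compound 3 `CC(C)n1cc(-c2ccnc3[nH]c(C4CCNCC4)cc23)ccc1=O` also sits at a limit in this assay, < 3 uL/min, so no number of its own is known for it. Of the three values shown, two rest at this same point, (the limit of < 3 uL/min in this assay, at which 2 of the 3 values shown sit). Compound 4 `CC(=O)N1CCC(c2cc3c(-c4ccc(=O)n(C(C)C)c4)ccnc3[nH]2)CC1` differs from compound 3 by acetyl in place of hydrogen on an amine nitrogen in a ring. Within the data shown here, no measured step touches this amine nitrogen in a ring: the one step available concerns the ring on an aromatic carbon, and compound 1, which carries a larger group on that nitrogen, differs from compound 3 in two places at once, so its value offers no clean comparison. Among the measured compounds shown here, with no bearing step in hand, the expected step for compound 4 is an at least 2.0-fold higher number from compound 3 to compound 4 (0.30 log units; that floor lies within the scatter) in this assay, meaning nothing clearly beyond the scatter. Compound 4 is therefore estimated at 6 uL/min in this assay, with a range from 3 uL/min to 15 uL/min.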

Compound 4, intrinsic clearance in a liver preparation (reported as CLH), per the amount of preparation that the assay uses: < 3 uL/min
Compound 4: only a limit was reported; the forecaster's own chance of this, stated with the estimate: 40%; at least 2.0-fold (0.30 log units) between middle value and limit.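

Among these compounds, compound 3 and compound 4 both sit at a limit in this assay, so the exchange of hydrogen for acetyl on the amine nitrogen in a ring gives no step that can be read: the limit of < 3 uL/min in this assay, at which 3 of the 4 values shown sit. The compounds shown leave open both the size and the direction of any change that acetyl brings on this nitrogen in this assay.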